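The source may report more compounds than this note shows. Statements on the series, on what has been measured and on what is new or still open speak of the compounds shown alone.

Compound 1 `CNC(=O)c1cc(C(=O)NC2CC2)cn(Cc2ccc(C)cc2)c1=O`: 24 ug/mL
Compound 2 `CNC(=O)c1cc(C(=O)NC2CC2)cn(Cc2cccc3cn[nH]c23)c1=O`: >= 181 ug/mL

In a physicochemical assay for solubility (on this read-out higher numbers stand for higher solubility and lower numbers for lower solubility), compound 1 gives 24 ug/mL. For compound 2 this assay reports only a limit, >= 181 ug/mL (the limit of >= 181 ug/mL in this assay, at which 1 of the 2 values shown sits). Compound 3 `CNC(=O)c1cc(C(=O)NC2CC2)cn(Cc2ccccc2F)c1=O` is not yet measured. Its change from compound 2 is 2-fluorophenyl in place of 1H-indazol-7-yl on a saturated chain carbon bound to an aromatic nitrogen. Among the compounds with values here, the one measured step that bears on it, an at least 7.5-fold higher number from compound 1 to compound 2 (0.87 log units; beyond the scatter), runs the opposite way, from a six-membered aromatic ring of carbon only to the 1H-indazol-7-yl group. A fall beyond the scatter is therefore expected, an at least 5.1-fold lower number from compound 2 to compound 3 (0.71 log units; beyond the scatter). Compound 3 is estimated at 35 ug/mL, within a range from 12 ug/mL to 110 ug/mL.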

Compound 3, solubility: >= 145 ug/mL
Compound 3 ended at the assay's limit; the forecaster's own chance of this, stated with the estimate: 10%; middle value at least 4.1-fold (0.61 log units) away from the limit.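

In this assay compound 3 gives >= 145 ug/mL as a limit, not a number. The change from 4-methylphenyl to 2-fluorophenyl gives an at least 6.0-fold higher number from compound 1 to compound 3 (0.78 log units; beyond the scatter) on this saturated chain carbon bound to an aromatic nitrogen, so the higher number here does not require 1H-indazol-7-yl, since 2-fluorophenyl has 0 hydrogen-bond donors. The step between compound 2 and compound 3 cannot be read, as both values are limits. As far as these compounds go, how far either compound lies past its limit stays open, as does what a carboxylic acid or an aminomethyl group would give in this place.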